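Shortening the Ester Chain on a Prenylated Quinone

The compounds below may be only part of what the source reports. "The series", "measured", "known", "first", "only" and "open" are said of these compounds alone.

Three compounds share one core and differ only in the group attached through oxygen at the chain carbon that carries the prenyl side chain. Compound 1 `COC(C)CO[C@H](CC=C(C)C)C1=CC(=O)c2c(O)ccc(O)c2C1=O` carries an ether; in a functional assay on DU-145 cells (Homo sapiens) for cytotoxicity, read by MTT assay (a higher number here means a weaker inhibitor, a lower number a stronger inhibitor), compound 1 gives 16600 nM. Compound 2 `CCCCC(CC(=O)O[C@H](CC=C(C)C)C1=CC(=O)c2c(O)ccc(O)c2C1=O)OC(C)=O` carries an ester with a 1-acetoxypentyl group; in this assay compound 2 gives 67700 nM. Compound 3 `CCCCCCC(C)(O)CC(=O)O[C@H](CC=C(C)C)C1=CC(=O)c2c(O)ccc(O)c2C1=O` carries an ester with a 1-hydroxy-1-methylheptyl group. In this assay compound 3 reaches only a limit of the assay, > 100000 nM, not a number. Among the measured compounds shown here, the one measured step, an at least 1.4-fold higher number from compound 2 to compound 3 (0.16 log units; that floor lies within the scatter), is sized only as a floor (the limit of > 100000 nM in this assay, at which 1 of the 3 values shown sits), so compound 3 stands at that limit with no firm figure of its own.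

Compound 4 `CCCC(C)(O)CC(=O)O[C@H](CC=C(C)C)C1=CC(=O)c2c(O)ccc(O)c2C1=O` differs from compound 3 by hydrogen in place of propyl on a saturated chain carbon, four bonds along the chain from an oxygen on a saturated carbon. For the measured compounds named here, no measured pair changes chain length alone, and the only sized step swaps one whole group for another and ends at a limit, so nothing measured bears directly on this change. The expected step is therefore an at least 1.2-fold lower number from compound 3 to compound 4 (0.09 log units; that floor lies within the scatter), essentially no movement beyond the scatter. Compound 4 is expected to give about 80000 nM, within 25000 nM to 300000 nM, with a fair chance of another limit.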

Compound 4, half-maximal inhibitory concentration: 75000 nM
The estimate for compound 4 lay 1.1-fold (0.03 log units) above the measured number, and the stated range covers the measured number.
By their numbers in this assay, from the lowest: compound 1; then compounds 2 and 4 (each within the scatter of the next). At a limit, above all of these: compound 3.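

In this assay, hydrogen in place of propyl gives an at least 1.3-fold lower number from compound 3 to compound 4 (0.12 log units; that floor lies within the scatter), which is only a floor and not the true size of the change: the limit of > 100000 nM in this assay, at which 1 of the 4 values shown sits. Compared with the ester in compound 2, the swap to 1-hydroxy-1-methylbutyl gives a 1.1-fold higher number from compound 2 to compound 4 (0.04 log units; within the scatter), so these two esters cannot be told apart in this assay. The ether in compound 1 stays clearly ahead, with (2-hydroxy-2-methylpentyl)carbonyl in place of 2-methoxypropyl giving a 4.5-fold higher number from compound 1 to compound 4 (0.65 log units; beyond the scatter).

As far as these compounds go, how far the true value of compound 3 lies past its limit remains open, and with it the real size of the propyl change. Also open, from the compounds shown here alone, is whether an amine or a carboxylic acid at this place on the chain would move the number beyond the scatter.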